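A few compounds are considered here, and "the series" means these few. Any claim that something is new, unique, unknown or untested is made for them only; others in the source may bear on it.

Compound 1 `Cc1cccc(C(=O)N2CCCC(C(=O)Nc3ccc(Cl)cc3)C2)c1` was tested in an ADME assay on PC-3 cells (Homo sapiens) for cytotoxicity, read by WST assay, tested at 100 uM (on this read-out higher numbers stand for more inhibition at the one concentration tested (going by the name of the read-out) and lower numbers for less inhibition), where compound 1 gives 0%. The nearest comparison is compound 2 `CSc1cccc(NC(=O)C2CCCN(C(=O)c3cc(C(F)(F)F)cc(C(F)(F)F)c3)C2)c1`, which in this assay gives 0%, so compound 1 stands level with compound 2 at the digits reported, with no change between them beyond the scatter. Compound 3 `COC(=O)c1cccc(C(=O)N2CCCC(C(=O)Nc3ccc(Cl)cc3)C2)c1` has not yet been measured in this assay. It differs from compound 1 by methoxycarbonyl in place of methyl on an aromatic carbon. Within the data shown here, no step between two measured compounds illustrates this change, and both measured compounds show no inhibition at the concentration tested in this assay. The step from compound 1 to compound 3 in this assay is expected to be no change at the digits printed from compound 1 to compound 3 (within the scatter), which is none beyond the scatter. Compound 3 is therefore estimated at 0% in this assay, with a range from -6% to 12%.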

Compound 3, a percentage reported as inhibition, at one concentration (the size of the read-out at that concentration, not a potency): 0%
Compound 3: middle estimate and measured number agree at the digits printed; the measured number falls inside the stated range.
By their numbers in this assay, from the lowest: compounds 1, 2 and 3 (each within the scatter of the next).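

In this assay, methoxycarbonyl in place of methyl on an aromatic carbon, meta to a large group, gives no change at the digits printed from compound 1 to compound 3 (within the scatter). This is the first step shown at this position, and it adds heavy atoms and hydrogen-bond acceptors without moving the read-out. Among these compounds, since compound 1 already showed no inhibition, the step shows only that this larger group does not bring any inhibition at the one concentration tested, and it cannot show whether the change would matter in a compound with measurable inhibition. No measurement of any property bears on this result.

The compounds shown leave open whether an amine or a carboxylic acid at this position would shift the read-out. With every compound at the same level, they also give no sign of which part of the structure, if any, governs it.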